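The compounds below may be only part of what the source reports. "The series", "measured", "known", "first", "only" and "open" are said of these compounds alone.

- Compound 1 `COc1cc(-c2nc3ccccc3s2)ccc1OCC(=O)NNC(=O)CN[C@@H](CS(=O)(=O)O)C(=O)O`: 3690 nM
- Compound 2 `COc1cc(-c2nc3ccccc3s2)ccc1OCC(=O)NNC(=O)CN[C@@H](CCSC)C(=O)O`: 3780 nM
- Compound 3 `CCOC(=O)CN(C)CC(=O)NNC(=O)COc1ccc(-c2nc3ccccc3s2)cc1OC`: 3180 nM

In a functional assay on HepG2 cells (Homo sapiens) for inhibition, read by MTT assay, with a stated time of 3 days (a higher number here means a weaker inhibitor, a lower number a stronger inhibitor), compound 3 gives 3180 nM and stands level with the other two compounds. The measured steps are a 1.2-fold lower number from compound 1 to compound 3 (0.06 log units; within the scatter) and a 1.2-fold lower number from compound 2 to compound 3 (0.08 log units; within the scatter), and neither lies beyond the scatter.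

Compound 4 `CCOC(=O)[C@H](NCC(=O)NNC(=O)COc1ccc(-c2nc3ccccc3s2)cc1OC)[C@@H](C)CC` keeps the shared core of compound 3 but carries (1-(ethoxycarbonyl)-2-methylbutyl)amino in place of ((ethoxycarbonyl)methyl)(methyl)amino on a saturated chain carbon bound to a carbonyl carbon.

Two measured steps exchange the substituent at this same place, and both are small, as shown above. A further change in the side chain, a 1.0-fold higher number from compound 1 to compound 2 (0.01 log units; within the scatter), is equally small. None of these compounds carries this exact group, so the evidence is indirect. Even so, sulfo and (methylsulfanyl)methyl side chains leave the numbers in this assay unmoved, so no step beyond the scatter is expected in either direction.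

The expected step is a 1.1-fold higher number from compound 3 to compound 4 (0.04 log units; within the scatter). Compound 4 is estimated at 3500 nM, within an expected range of 1800 nM to 6800 nM.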

Compound 4, half-maximal inhibitory concentration: 3970 nM
Beside the measured number, compound 4's estimate is 1.1-fold (0.05 log units) below it; the range from low to high includes it.
By their numbers in this assay, from the lowest: compounds 3, 1, 2 and 4 (each within the scatter of the next).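

Measured in this assay, the exchange of ((ethoxycarbonyl)methyl)(methyl)amino for (1-(ethoxycarbonyl)-2-methylbutyl)amino gives a 1.2-fold higher number from compound 3 to compound 4 (0.10 log units; within the scatter) and so extends the flat picture to a group of 11 heavy atoms that has 1 hydrogen-bond donor and 2 defined stereocentres. The comparisons with the carboxy-bearing side chains are equally small: a 1.1-fold higher number from compound 2 to compound 4 (0.02 log units; within the scatter) for 1-(ethoxycarbonyl)-2-methylbutyl in place of 1-carboxy-3-(methylsulfanyl)propyl and a 1.1-fold higher number from compound 1 to compound 4 (0.03 log units; within the scatter) for the same group in place of 1-carboxy-2-sulfoethyl show that an ethyl ester on the amine nitrogen substituent also leaves the number level in these pairs. Nothing available explains why the number stays level at this position.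

The compounds shown leave open whether a side chain ending in a primary amine or carrying a phenyl ring would stay equally level. They also leave open whether the opposite configuration at the two stereocentres of compound 4 would change the number.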